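The source may report more compounds than this note shows. Statements on the series, on what has been measured and on what is new or still open speak of the compounds shown alone.

Of the compounds shown here, three have been measured in a functional assay on CHO cells for agonist activity at Alpha-1A adrenergic receptor (Homo sapiens), read by FLIPR and calcium flux; a lower number here means that less compound is needed, a higher number that more compound is needed for the effect. Compound 1, with the structure `Cc1c(OCC2=NCCN2)ccc(Cl)c1NS(C)(=O)=O`, gives 25 nM in this assay. Compound 2, with the structure `Cc1oncc1-c1cccc2c1CCC2c1ncc[nH]1`, gives 111 nM. Compound 3, with the structure `CCS(=O)(=O)Nc1cccc(Cc2c[nH]cn2)c1`, gives 9 nM. Among these three numbers compound 2 has the highest, so the most compound is needed for the effect there; its gap to compound 1 and its larger gap to compound 3 both go beyond the usual scatter of repeated measurements, so compound 2 is genuinely the weakest of the three.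

The next compound to consider is compound 4, with the structure `Cn1nccc1-c1cccc2c1CCC2c1ncc[nH]1`. It keeps the core of compound 2 and differs in a single place: 1-methyl-1H-pyrazol-5-yl in place of 5-methyl-1,2-oxazol-4-yl on an aromatic carbon. The group that leaves and the group that enters are of the same size, each a five-membered aromatic ring with two hetero atoms and two hydrogen-bond acceptors, with no hydrogen-bond donor and no charge on either side.

For the measured compounds named here, no measured pair in this set shows the effect of such an exchange, so the expected step in this assay is small: a 1.0-fold lower number from compound 2 to compound 4 (0.00 log units; within the scatter), a change not expected to reach beyond the scatter. Compound 4 is therefore estimated at 110 nM, with a range from 35 nM to 350 nM.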

Compound 4, half-maximal effective concentration: 278 nM
The estimate for compound 4 lay 2.5-fold (0.40 log units) below the measured number; low and high end bracket the measured number.
By their numbers in this assay, from the lowest: compound 3; then compound 1; then compound 2; then compound 4.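

In this assay, for the compounds shown here, placing 1-methyl-1H-pyrazol-5-yl instead of 5-methyl-1,2-oxazol-4-yl on this aromatic carbon gives a 2.5-fold higher number from compound 2 to compound 4 (0.40 log units; beyond the scatter), the first step in this set that isolates a change in one place. It shows that this position on the shared core is sensitive to the identity of the ring it carries, even though the two groups have the same heavy-atom, hydrogen-bond donor and hydrogen-bond acceptor counts, and both are five-membered aromatic rings with two hetero atoms. Matching these counts is therefore not enough to keep the number unchanged, and nothing available here accounts for this step.

The compounds shown leave open how this position behaves with groups of a different kind, such as a simple phenyl ring, a primary amine or a carboxylic acid, and whether a smaller group or plain hydrogen would bring the number down or push it up. Going by these compounds alone, they also leave open whether the same exchange would give a similar step on another core, since this single pair is the only example of it.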